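A few compounds are considered here, and "the series" means these few. Any claim that something is new, unique, unknown or untested is made for them only; others in the source may bear on it.

Measured in a functional assay on HeLa cells (Homo sapiens) for cytotoxicity, read by MTT assay, with a stated time of 48 h; a higher number here means a weaker inhibitor, a lower number a stronger inhibitor:
- compound 1 `Cc1n[nH]c2c1C(c1ccc(N(C)C)cc1)C(C(=O)n1ncc(C#N)c1N)=C(N)N2`: 60200 nM
- compound 2 `Cc1n[nH]c2c1C(c1ccc(N(C)C)cc1)C=C(N)N2`: 27400 nM

Compound 2, at 27400 nM, has the lower of the two numbers, which makes it the stronger inhibitor of the pair. The next compound, compound 3 `Cc1n[nH]c2c1C(c1ccc(N(C)C)cc1)C(C(=O)O)=C(N)N2`, keeps the core of compound 2 and carries a single change: carboxy in place of hydrogen on a double-bonded ring carbon. In words, this is carboxy in place of hydrogen on a double-bonded ring carbon.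

Among the compounds with values here, only one measured step bears on this change: a 2.2-fold lower number from compound 1 to compound 2 (0.34 log units; beyond the scatter). That step is modest, and it takes a (5-amino-4-cyano-1H-pyrazol-1-yl)carbonyl off the same ring carbon that gains carboxy in compound 3. Within the data shown here, the two groups are very different in size, and no measured compound carries carboxy, so this comparison is only a loose guide. Going by compound 1 at 60200 nM, a modest rise in the number in this assay is expected, meaning a somewhat weaker inhibitor. The expected step is a 2.2-fold higher number from compound 2 to compound 3 (0.34 log units; beyond the scatter). For compound 3 the estimated value is 60000 nM, with an expected range from 22000 nM to 150000 nM.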

Compound 3, half-maximal inhibitory concentration: 33600 nM
Beside the measured number, compound 3's estimate is 1.8-fold (0.25 log units) above it, within the range that was stated.
By their numbers in this assay, from the lowest: compounds 2, 3 and 1 (each within the scatter of the next, the first and the last beyond it).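

Placing carboxy on the double-bonded ring carbon gives a 1.2-fold higher number from compound 2 to compound 3 (0.09 log units; within the scatter) in this assay, so at this position a group of 3 heavy atoms cannot be told apart from a bare hydrogen. Exchanging the 5-amino-4-cyano-1H-pyrazol-1-yl for hydroxy on the carbonyl carbon gives a 1.8-fold lower number from compound 1 to compound 3 (0.25 log units; within the scatter) and likewise stays inside the usual scatter, which means compound 3 cannot be separated from either neighbour even though compound 1 and compound 2 differ beyond the scatter; the earlier gap between those two therefore does not resolve into a clear effect of either the carbonyl or the pyrazole part once compound 3 stands between them. Nothing available here explains why these numbers fall as they do.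

The compounds shown leave open whether any group at this ring carbon can move the number clearly beyond the scatter in either direction, since a single carboxy example and a single large acyl group give only a thin picture. A methyl ester or a primary amide on the same carbonyl carbon, or a plain nitrile directly on the ring carbon, would test this further.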